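Aryl for Chlorine on the Salicylanilide Core

The source may hold more compounds than are shown below. What is called first, only, known or untested is meant among the compounds shown, and "the series" means these compounds.

Measured compounds:
compound 1 `N#Cc1ccc(NC(=O)c2ccc(Cl)cc2O)cc1`: 1920 nM
compound 2 `O=C(Nc1ccc(C(F)(F)F)cc1)c1ccc(Cl)cc1O`: 580 nM
compound 3 `N#Cc1ccc(NC(=O)c2cc(Cl)c(-c3ccccc3)cc2O)cc1`: 480 nM

In a functional assay on KG-1 cells (Homo sapiens) for cytotoxicity, read by luminescence and CellTiter-Glo, with a stated time of 3 days (on this read-out higher numbers stand for weaker inhibition and lower numbers for stronger inhibition), compound 1 gives 1920 nM, the highest of the three numbers; compound 2 sits at 580 nM and compound 3 at 480 nM, both beyond the scatter away from it. Within the data shown here, the one step measured in a single place, a 3.3-fold lower number from compound 1 to compound 2 (0.52 log units; beyond the scatter), concerns the other end of the shared core and does not touch the site changed here. Compound 4 `N#Cc1ccc(NC(=O)c2ccc(-c3ccncc3)cc2O)cc1` differs from compound 1 as follows: pyridin-4-yl in place of chloro on an aromatic carbon. Among the measured compounds shown here, no measured step covers this exchange directly. Compound 3, which carries a phenyl on the same ring as its chlorine, shows a lower number than compound 1, and that is the only hint available about an aryl group on this ring. A modest fall in the number is therefore expected, a 2.4-fold lower number from compound 1 to compound 4 (0.38 log units; beyond the scatter), though with wide uncertainty. For compound 4 the estimate is 800 nM, within a range from 250 nM to 2500 nM.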

Compound 4, half-maximal inhibitory concentration: 8840 nM
Compound 4: middle estimate off by 11-fold (1.04 log units), on the low side, and the stated range ends below it.
By their numbers in this assay, from the lowest: compounds 3 and 2 (each within the scatter of the next); then compound 1; then compound 4.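

In this assay the exchange of chloro for pyridin-4-yl gives a 4.6-fold higher number from compound 1 to compound 4 (0.66 log units; beyond the scatter) at a place meta to a hydroxy group and para to a large group. Among these compounds, this is the only direct reading at this position, and it shows that the core of compound 1 does not keep its number when this larger aromatic ring, with its one hetero atom, replaces the halogen. No measurement shown here accounts for the rise.

With only one aryl group at this position, the compounds shown cannot separate the effect of the ring nitrogen from that of the ring itself. Phenyl or pyridin-3-yl in place of chloro on the same core, or a smaller group such as methoxy or an amine, remains open.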